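The source may hold more compounds than are shown below. What is called first, only, known or untested is meant among the compounds shown, and "the series" means these compounds.

Going by the values given here, in a functional assay on MIA PaCa-2 cells (Homo sapiens) for antiproliferative activity, read by resazurin assay, with a stated time of 70 h (on this read-out lower numbers stand for stronger inhibition and higher numbers for weaker inhibition), compound 2, `[O-][S+](CC#Cc1ccccc1)c1c(F)c(F)c(F)c(F)c1F`, gives 7800 nM, the only exact number so far. Compound 1, `[O-][S+](CC#Cc1ccccc1C#CCCCCO)c1c(F)c(F)c(F)c(F)c1F`, is reported only as a limit, > 10000 nM.

The next compound in the series, compound 3, `[N-]=[N+]=NCC#Cc1ccccc1C#CC[S+]([O-])c1c(F)c(F)c(F)c(F)c1F`, departs from compound 2 by a single change, (3-azidoprop-1-yn-1-yl in place of hydrogen on an aromatic carbon). A 3-azidoprop-1-yn-1-yl group takes the place of hydrogen on an aromatic carbon, ortho to a large group.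

Among the compounds with values here, one measured step bears on this change. In an at least 1.2-fold lower number from compound 1 to compound 2 (0.10 log units; that floor lies within the scatter), hydrogen replaces a 6-hydroxyhex-1-yn-1-yl group on an aromatic carbon. That step rests on a limit, and its floor lies within the scatter, so it shows no firm effect of placing such a chain on the core. Within the data shown here, with an at least 1.2-fold lower number from compound 1 to compound 2 (0.10 log units; that floor lies within the scatter) as the only guide, no step beyond the scatter is expected in this assay, though any drift would be expected towards weaker inhibition. The expected change is a 1.2-fold higher number from compound 2 to compound 3 (0.06 log units; within the scatter). For compound 3 the estimated value is 9000 nM, with an expected range from 3000 nM to 25000 nM.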

Compound 3, half-maximal inhibitory concentration: 2400 nM
Estimate against measurement, compound 3: 3.8-fold (0.57 log units) above; the whole stated range lies above it.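

In this assay, placing 3-azidoprop-1-yn-1-yl on this aromatic carbon, ortho to a large group, gives a 3.3-fold lower number from compound 2 to compound 3 (0.51 log units; beyond the scatter). This shows that a substituent at this position can go with stronger inhibition, which the earlier step, resting on a limit with its floor within the scatter, could not show. The chain end also counts here, as azido in place of 3-hydroxypropyl gives an at least 4.1-fold lower number from compound 1 to compound 3 (0.61 log units; beyond the scatter), but that figure is only a floor, and compound 1 is reported as a limit: the limit of > 10000 nM in this assay, at which 1 of the 3 values shown sits.

The compounds shown leave open whether the azido group or the shorter chain carries the difference between compound 1 and compound 3, as the two change together in that step. As far as these compounds go, how an amine or a hydroxyl in place of the azido group on the same short chain would read in this assay also stays open, and with it whether the azido group itself is needed for the stronger inhibition of compound 3.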